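Bromo for hydroxymethyl on the shared core

The compounds below may be only part of what the source reports. "The series", "measured", "known", "first", "only" and "open" are said of these compounds alone.

Three compounds of the series have been run in a functional assay on the whole organism (stomach) for inhibition, with Canis familiaris (Canis lupus familiaris) as the target, at a dose of 5 mg/kg by the intravenous route; a higher number here means a stronger effect of the compound at the dose given, a lower number a weaker effect. Compound 1 `Cc1nc2c(OCc3ccccc3)cccn2c1CO` gives 80% and stands highest of the three numbers. Compound 3 `Cc1nc2c(OCc3ccccc3)cccn2c1Cl` gives 37%, and compound 2 `CCSCc1c(C)nc2c(OCc3ccccc3)cccn12` gives 0%. Both steps away from compound 1 are large: a number 43 percentage points lower from compound 1 to compound 3 (beyond the scatter), and a number 80 percentage points lower from compound 1 to compound 2 (beyond the scatter). The third step runs upward: a number 37 percentage points higher from compound 2 to compound 3 (beyond the scatter).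

Compound 4 `Cc1nc2c(OCc3ccccc3)cccn2c1Br` has not been run. It differs from compound 1 by bromo in place of hydroxymethyl on an aromatic carbon. The measured step that bears most directly on it is a number 43 percentage points lower from compound 1 to compound 3 (beyond the scatter), where a single halogen likewise took the place of the hydroxymethyl group; the step of a number 80 percentage points lower from compound 1 to compound 2 (beyond the scatter) shows that losing the hydroxy group on that chain removed the whole effect. A large downward step from compound 1 in this assay is therefore expected for compound 4, of about the size seen for the chloro case. For compound 4 the expected step is a number 45 percentage points lower from compound 1 to compound 4 (beyond the scatter). The estimate for compound 4 is 35%, with a range from 15% to 60%.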

Compound 4, a percentage reported as inhibition, in the whole organism at one dose (the size of the read-out at that dose, not a potency): 63%
Compound 4: middle estimate off by 28 percentage points, on the low side, and the stated range ends below it.
By their numbers in this assay, from the lowest: compound 2; then compound 3; then compound 4; then compound 1.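

In this assay, the hydroxy group on this carbon proves not to be needed for a substantial effect: with bromo on the aromatic carbon, which adds no hydrogen-bond donor, the read-out shows a number 17 percentage points lower from compound 1 to compound 4 (beyond the scatter). The two halogens are not interchangeable at this position, with a number 26 percentage points higher from compound 3 to compound 4 (beyond the scatter), while a number 63 percentage points higher from compound 2 to compound 4 (beyond the scatter), so the complete loss seen with (ethylsulfanyl)methyl cannot be read as a simple result of removing the hydroxy group. No measurement at hand accounts for the gap between bromo and chloro.

Going by these compounds, how iodo, an aminomethyl group or a longer hydroxyalkyl chain would stand at this position remains open. These read-outs also describe the effect at a single dose, leaving the potency of the compounds open.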